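This account rests on a few compounds, and the source may have more. Where it says the series, first, only, none or still open, it means among the compounds named here.

Among the compounds with values here, compound 3 `Oc1ccc(-c2cc(-c3ccccn3)cc(-c3cccc(O)c3)n2)cc1` gives 980 nM in a functional assay on T47D cells (Homo sapiens) for cytotoxicity, read by CCK-8 assay (a higher number here means a weaker inhibitor, a lower number a stronger inhibitor), the lowest of the three numbers measured so far. Compound 1 `Oc1ccc(-c2cc(-c3ccsc3)cc(-c3ccc(O)cc3)n2)cc1` gives 1770 nM in this assay, which sits within the scatter of compound 3, so these two cannot be placed in order. Compound 2 `Oc1ccc(-c2cc(-c3ccco3)cc(-c3ccc(O)cc3)n2)cc1` gives 21100 nM in this assay, the furthest from compound 3 and beyond the scatter. Within the data shown here, the only step measured between neighbouring structures is a 12-fold higher number from compound 1 to compound 2 (1.08 log units; beyond the scatter); it concerns the five-membered ring on the shared core and leaves both hydroxyphenyl groups untouched, so it says nothing about the change considered here.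

Compound 4 `Oc1ccc(-c2cc(-c3ccccn3)cc(-c3ccc(O)cc3)n2)cc1` is not yet measured. The change from compound 3 is 4-hydroxyphenyl in place of 3-hydroxyphenyl on an aromatic carbon. Among the measured compounds shown here, no measured pair differs in this way, and compounds 1 and 2 carry two 4-hydroxyphenyl groups without a 3-hydroxyphenyl partner to compare against, so the data give no measured step on which to build a direction. Compound 4 is thus expected to show a step that stays within the scatter, a 1.0-fold higher number from compound 3 to compound 4 (0.01 log units; within the scatter). For compound 4 the estimate in this assay is 1000 nM, with a range from 400 nM to 2500 nM.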

Compound 4, half-maximal inhibitory concentration: 1040 nM
The estimate for compound 4 lay 1.0-fold (0.02 log units) below the measured number, within the range that was stated.
By their numbers in this assay, from the lowest: compounds 3, 4 and 1 (each within the scatter of the next); then compound 2.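

On the aromatic carbon next to the ring nitrogen, with pyridin-2-yl on the shared core, 4-hydroxyphenyl in place of 3-hydroxyphenyl gives a 1.1-fold higher number from compound 3 to compound 4 (0.03 log units; within the scatter) in this assay and leaves the two compounds without an order, so this change of hydroxyl placement shows no readable effect in this pair. Compound 4 also sets pyridin-2-yl against the five-membered rings with both 4-hydroxyphenyl groups kept: the swap from furan-2-yl gives a 20-fold lower number from compound 2 to compound 4 (1.31 log units; beyond the scatter) while the swap from thiophen-3-yl gives a 1.7-fold lower number from compound 1 to compound 4 (0.23 log units; within the scatter) and leaves those two compounds without an order, so among the compounds shown only the furan-2-yl compound stands apart. No evidence is available that explains either the flat hydroxyl change or the large furan-2-yl step.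

As far as these compounds go, whether the hydroxyl change would stay equally silent with furan-2-yl or thiophen-3-yl on the core remains open, since this single pair carries pyridin-2-yl. Also open, from the compounds shown here alone, is whether a methoxy group or an amine in place of the hydroxyl on this phenyl group would keep the number in the same range.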